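Chloro for iodo on the shared core of compound 2

The source may hold more compounds than are shown below. What is called first, only, known or untested is meant among the compounds shown, and "the series" means these compounds.

Measured so far:
compound 1 `O=C(O)/C(S)=C/c1c[nH]c2c(F)cccc12` — 120 nM
compound 2 `O=C(O)/C(S)=C/c1c[nH]c2ccc(I)cc12` — 100 nM
compound 3 `O=C(O)/C(S)=C/c1ccccc1Br` — 21000 nM

In an assay on isolated protein for inhibition of Calpain-1 catalytic subunit (Sus scrofa), read by FRET (on this read-out higher numbers stand for weaker inhibition and lower numbers for stronger inhibition), compound 2 gives the lowest number of the three, but its gap to compound 1 falls within the usual scatter, so the two are not separated. Compound 3, which lacks the fused two-ring core, sits far weaker. Compound 4 `O=C(O)/C(S)=C/c1c[nH]c2ccc(Cl)cc12` differs from compound 2 by chloro in place of iodo on an aromatic carbon. Within the data shown here, no measured pair shows this change, so its effect can only be expected, not read off. The two fused-core compounds give close numbers with different halogens at different places, which suggests halogen identity here matters little. Hence no step beyond the scatter is expected, and the step of a 1.5-fold higher number from compound 2 to compound 4 (0.18 log units; within the scatter) is estimated as small. Compound 4 is expected to give 150 nM in this assay, within 60 nM to 400 nM.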

Compound 4, half-maximal inhibitory concentration: 250 nM
Estimate against measurement, compound 4: 1.7-fold (0.22 log units) below; the range from low to high includes it.
By their numbers in this assay, from the lowest: compounds 2 and 1 (each within the scatter of the next); then compound 4; then compound 3.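

Among these compounds, this pair gives the first direct reading at this aromatic carbon: in this assay, chloro in place of iodo brings a 2.5-fold higher number from compound 2 to compound 4 (0.40 log units; beyond the scatter). Among the compounds shown here, the step is modest, but it shows that the two halogens are not interchangeable here, which the earlier compounds, differing in more than one place, could not show. No measurement at hand accounts for the step. The compounds shown leave open how an amine or a methoxy group on this carbon would read. From the compounds shown here alone, whether chloro in place of iodo gives a similar step on another core also remains open.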